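This account rests on a few compounds, and the source may have more. Where it says the series, first, only, none or still open, it means among the compounds named here.

The series shares one core, with a single aryl group varied. Compound 1 `Cc1nc2c3ccccc3ccc2c2nc3c(ccc4ccccc43)c(-c3nccnc3N)c12` carries a 3-aminopyrazin-2-yl group and in a functional assay, read by spectrophotometry, with a stated time of 30 min (on this read-out higher numbers stand for weaker inhibition and lower numbers for stronger inhibition), compound 1 gives 81.7 ug/mL. Compound 2 `COc1ccc(-c2c3ccc4ccccc4c3nc3c2c(C)nc2c4ccccc4ccc32)cc1` carries a 4-methoxyphenyl group; in this assay compound 2 gives 133 ug/mL. Compound 3 `Cc1nc2c3ccccc3ccc2c2nc3c(ccc4ccccc43)c(-c3cc([N+](=O)[O-])ccc3N)c12` carries a 2-amino-5-nitrophenyl group; in this assay compound 3 gives 93.1 ug/mL. Compound 3 sits nearest to compound 1, with a 1.1-fold higher number from compound 1 to compound 3 (0.06 log units; within the scatter), and its widest separation is from compound 2, with a 1.4-fold lower number from compound 2 to compound 3 (0.15 log units; within the scatter); all three values lie within the usual scatter of one another.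

Compound 4 `Cc1ccc(-c2c3ccc4ccccc4c3nc3c2c(C)nc2c4ccccc4ccc32)cc1` is not yet measured. (4-methylphenyl in place of 2-amino-5-nitrophenyl on an aromatic carbon). For the measured compounds named here, the step bearing most directly on it is the one between compound 2 and compound 3, a 1.4-fold lower number from compound 2 to compound 3 (0.15 log units; within the scatter), read in reverse, since the group entering in compound 4 resembles that of compound 2; a 1.6-fold higher number from compound 1 to compound 2 (0.21 log units; within the scatter) is of the same kind. Neither step leaves the scatter, so no change beyond the scatter is expected in this assay. Compound 4 is estimated at 125 ug/mL, with a range of 65 ug/mL to 240 ug/mL. The expected step is therefore a 1.3-fold higher number from compound 3 to compound 4 (0.13 log units; within the scatter).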

Compound 4, half-maximal inhibitory concentration: 123 ug/mL
Compound 4: the middle estimate sits 1.0-fold (0.01 log units) above what was measured, and the stated range covers the measured number.
By their numbers in this assay, from the lowest: compounds 1, 3, 4 and 2 (each within the scatter of the next).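

For the compounds shown here, compound 4 is the first group here made of carbon only, and in this assay the change from 2-amino-5-nitrophenyl to 4-methylphenyl, which removes the donor and all acceptors of the leaving group, stays within the scatter (a 1.3-fold higher number from compound 3 to compound 4 (0.12 log units; within the scatter)). The same holds against the 3-aminopyrazin-2-yl group (a 1.5-fold higher number from compound 1 to compound 4 (0.18 log units; within the scatter)), and methyl in place of methoxy, the narrowest change so far at this position, also stays within the scatter (a 1.1-fold lower number from compound 2 to compound 4 (0.03 log units; within the scatter)). No measurement at hand offers any account of these steps.

Going by these compounds, whether any group at this position can move the number beyond the scatter stays open, since all four compounds carry a six-membered aromatic ring there. A carboxylic acid on that ring, or a saturated amine such as piperidine or a longer alkyl chain in its place, would test this.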